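The source may report more compounds than this note shows. Statements on the series, on what has been measured and on what is new or still open speak of the compounds shown alone.

Measured so far in a functional assay on MCF7 cells (Homo sapiens) for cytotoxicity, read by MTT assay, with a stated time of 72 h; a lower number here means a stronger inhibitor, a higher number a weaker inhibitor:
compound 1, `FC(F)(F)c1ccc(CSc2nc(Nc3ccc(Cl)cc3)c3ccccc3n2)cc1`, gives 21500 nM
compound 2, `COc1ccc(Nc2nc(SCc3ccc(C(F)(F)F)cc3)nc3ccccc23)cc1`, gives 47200 nM
compound 3, `COc1cc(Nc2nc(SCc3ccc(C(F)(F)F)cc3)nc3ccccc23)cc(OC)c1`, gives 6990 nM

Compound 3 holds the lowest number of the three; both steps that end at it lie beyond the scatter: a 3.1-fold lower number from compound 1 to compound 3 (0.49 log units; beyond the scatter) and a 6.8-fold lower number from compound 2 to compound 3 (0.83 log units; beyond the scatter). Among the compounds with values here, the one step among the other two is smaller and runs the other way: a 2.2-fold higher number from compound 1 to compound 2 (0.34 log units; beyond the scatter).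

Compound 4, `COc1cc(Nc2nc(SCc3ccc(C(F)(F)F)cc3)nc3ccccc23)cc(OC)c1OC`, differs from compound 3 by methoxy in place of hydrogen on an aromatic carbon. Within the data shown here, no measured step adds a methoxy group at a place that already carries two; the nearest guide is the step from compound 2 to compound 3, where adding methoxy on the anilino ring brought the number down well beyond the scatter, while the step from compound 1 to compound 2 shows that a single methoxy exchange can also move the number up. On balance a modest downward step is expected, a 1.7-fold lower number from compound 3 to compound 4 (0.24 log units; within the scatter), in this assay. Compound 4 is therefore estimated at about 4000 nM, with a range from 1500 nM to 12000 nM.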

Compound 4, half-maximal inhibitory concentration: > 50000 nM
Compound 4 ended at the assay's limit; the forecaster's own chance of this, stated with the estimate: 5%; middle value at least 12-fold (1.09 log units) from the limit.
By their numbers in this assay, from the lowest: compound 3; then compound 1; then compound 2. At a limit, above all of these: compound 4.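

In this assay, methoxy in place of hydrogen on an aromatic carbon, ortho to two methoxy groups and para to a large group, gives an at least 7.1-fold higher number from compound 3 to compound 4 (0.85 log units; beyond the scatter). Methoxy count on this ring therefore does not track with a lower number: the earlier pair gave a 6.8-fold lower number from compound 2 to compound 3 (0.83 log units; beyond the scatter), and the added methoxy group here moves the number the opposite way. Compound 4 stands at a limit of the assay and not at a number: the limit of > 50000 nM in this assay, at which 1 of the 4 values shown sits.

Open, on these data alone, is whether a hydroxyl group or an amine on this same carbon would keep the number of compound 3, 6990 nM, or raise it. The compounds shown also do not tell why the number rose, or how far the true value of compound 4 lies from that of compound 3.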